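This account rests on a few compounds, and the source may have more. Where it says the series, first, only, none or still open, it means among the compounds named here.

Compound 1 `CCC(C)OC(=O)C1=C(C)NC(=O)NC1c1ccco1`, 6%; compound 2 `CC1=C(C(=O)OC2CCC2)C(c2ccco2)NC(=O)N1`, 19%; compound 3 `CCC(C)OC(=O)C1=C(C)NC(=O)NC1c1ccsc1`, 5%.

All three were measured in an assay on membranes from CHO cells for displacement of a labelled ligand from adenosine receptor A1 (Homo sapiens), read by scintillation counting, with a stated time of 60 min, tested at 1 uM; a higher number here means more inhibition at the concentration tested (going by the name of the read-out), a lower number less inhibition. Compound 4 `CC1=C(C(=O)OC2CCC2)C(c2ccsc2)NC(=O)N1` has not yet been measured in this assay. It differs from compound 3 by cyclobutyl in place of sec-butyl on an oxygen next to a carbonyl group. This is the same change that turns compound 1 into compound 2, (cyclobutyl in place of sec-butyl on an oxygen next to a carbonyl group), and there it gave a number 13 percentage points higher from compound 1 to compound 2 (beyond the scatter). The two cores on which the change is made differ by thiophen-3-yl in place of furan-2-yl on a saturated ring carbon, a difference that gave a number 1 percentage points lower from compound 1 to compound 3 (within the scatter), so the two starting points stand close together. For the measured compounds named here, compound 4 is therefore expected to show a step of about a number 12 percentage points higher from compound 3 to compound 4 (beyond the scatter), resting on the single earlier instance of the change, because a number 13 percentage points higher from compound 1 to compound 2 (beyond the scatter). For compound 4 the estimated value in this assay is 17%, expected to fall between 5% and 30%.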

Compound 4, a percentage reported as inhibition, at one concentration (the size of the read-out at that concentration, not a potency): 40%
For compound 4 the middle estimate is 23 percentage points below the measured one, and the stated range ends below it.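

Cyclobutyl in place of sec-butyl gives a number 35 percentage points higher from compound 3 to compound 4 (beyond the scatter) in this assay, so the step keeps its direction on the second core but does not keep its size: the same change on two cores in this assay, a number 13 percentage points higher (beyond the scatter) from compound 1 to compound 2 and a number 35 percentage points higher (beyond the scatter) from compound 3 to compound 4, 22 percentage points apart, beyond the scatter of two such steps. Read the other way, thiophen-3-yl in place of furan-2-yl gives a number 21 percentage points higher from compound 2 to compound 4 (beyond the scatter), whereas the same swap made no step beyond the scatter with sec-butyl in place: the same change on two cores in this assay, a number 1 percentage points lower (within the scatter) from compound 1 to compound 3 and a number 21 percentage points higher (beyond the scatter) from compound 2 to compound 4, 22 percentage points apart, beyond the scatter of two such steps. The two changes therefore do not add up independently in these four compounds, though the data do not show why, nor which size of step would hold on a further core.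

The compounds shown leave open how other groups on that oxygen, such as cyclopentyl or a longer chain, would behave. They also leave open whether a phenyl ring on the saturated ring carbon would show the same dependence.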